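The source may hold more compounds than are shown below. What is called first, only, known or untested is meant among the compounds shown, and "the series" means these compounds.

In an ADME assay on HEp-2 cells (Homo sapiens) for cytotoxicity, read by MTT assay, with a stated time of 72 h (a lower number here means a stronger inhibitor, a higher number a weaker inhibitor), only one of the three measured compounds gives an actual number. Compound 3 (`COCOc1cc(C2=C(c3cc(OC)c(OC)c(OC)c3)C(=O)CC2O[SiH2]C(C)(C)C)ccc1OC`) gives 12 ug/mL, and that is the only number shown. Compound 1 (`COc1cc(C2=C(c3cc(C)c(OC)c(C)c3)C(OC(C)=O)CC2=O)cc(OC)c1OC`) gives > 100 ug/mL, which is a limit of the assay. Compound 2 (`COc1ccc(C2=C(c3cc(OC)c(OC)c(OC)c3)C(=O)CC2O[SiH2]C(C)(C)C)cc1OC`) gives > 100 ug/mL, which is also a limit.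

Compound 4 (`COc1cc(C2=C(c3cc(C)c(OC)c(C)c3)C(O[SiH2]C(C)(C)C)CC2=O)cc(OC)c1OC`) departs from compound 3 with 4-methoxy-3,5-dimethylphenyl in place of 4-methoxy-3-(methoxymethoxy)phenyl on a double-bonded ring carbon. The measured step that bears most directly on this is an at least 8.3-fold lower number from compound 2 to compound 3 (0.92 log units; beyond the scatter), the change that adds the methoxymethoxy group, and compound 4 gives that group up. Compound 1, which already carries 4-methoxy-3,5-dimethylphenyl, stands at > 100 ug/mL, a limit of the assay. Both observations point the same way in this assay, so a higher number is expected, by a margin similar to the step that the methoxymethoxy group accompanied, and a reading that reports only a limit would be no surprise. The expected change is a 5.0-fold higher number from compound 3 to compound 4 (0.70 log units; beyond the scatter). For compound 4 the estimate is 60 ug/mL, with an expected range of 15 ug/mL to 200 ug/mL.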

Compound 4, half-maximal inhibitory concentration: 26 ug/mL
Beside the measured number, compound 4's estimate is 2.3-fold (0.36 log units) above it; the range from low to high includes it.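

In this assay, the result shows that the methoxymethoxy group is not the only route to a measured number at this double-bonded ring carbon: putting 4-methoxy-3,5-dimethylphenyl in place of 4-methoxy-3-(methoxymethoxy)phenyl gives a 2.2-fold higher number from compound 3 to compound 4 (0.34 log units; beyond the scatter), a modest loss and far from a return to the limit of the assay. For the compounds shown here, the same 4-methoxy-3,5-dimethylphenyl group also reads differently from 3,4-dimethoxyphenyl at this carbon, with an at least 3.8-fold lower number from compound 2 to compound 4 (0.58 log units; beyond the scatter), so the earlier step from compound 2 to compound 3 no longer stands alone as the only change that moves the number here. On the oxygen on a saturated carbon, the group of 5 heavy atoms in place of the group of 3 heavy atoms gives an at least 3.8-fold lower number from compound 1 to compound 4 (0.58 log units; beyond the scatter), which shows that 4-methoxy-3,5-dimethylphenyl can carry a measured number with one group there and not with the other.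

The true size of these last two steps stays open, as each starts from a limit: the limit of > 100 ug/mL in this assay, at which 2 of the 4 values shown sit. What the compounds shown also leave open is how a free hydroxyl or an amine on this aromatic ring would read, in place of the methoxymethoxy group or the methyl groups.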